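Enone series: trimming a methoxy from the carbonyl aryl

This account rests on a few compounds, and the source may have more. Where it says the series, first, only, none or still open, it means among the compounds named here.

The series keeps one shared core and varies the aryl on the carbonyl carbon. In a functional assay on SN12C cells (Homo sapiens) for cytotoxicity, read by sulforhodamine B assay, with a stated time of 48 h, tested at 100 uM (on this read-out higher numbers stand for a weaker effect at the one concentration tested and lower numbers for a stronger effect), compound 1 `COc1cc(-c2cc(/C=C/C(=O)c3ccc(N)cc3)[nH]n2)cc(OC)c1OC` gives -86%, compound 2 `COc1cc(-c2cc(/C=C/C(=O)c3ccc(Cl)c(Cl)c3)[nH]n2)cc(OC)c1OC` gives 11% and compound 3 `COc1ccc(C(=O)/C=C/c2cc(-c3cc(OC)c(OC)c(OC)c3)n[nH]2)cc1OC` gives -86%. Compound 3 stands level with compound 1, the two together the lowest of the three numbers: no change at the digits printed from compound 1 to compound 3 (within the scatter), whereas a number 97 percentage points lower from compound 2 to compound 3 (beyond the scatter). Compound 4 `COc1ccc(C(=O)/C=C/c2cc(-c3cc(OC)c(OC)c(OC)c3)n[nH]2)cc1` is the next step, (hydrogen in place of methoxy on an aromatic carbon). Within the data shown here, no measured step removes a methoxy from this aryl; the pair compound 1 and compound 3 shows that quite different groups on this aryl give the same read-out, while compound 2 shows the tolerance is not unlimited. Compound 4 is therefore expected to stay close to compound 3, with a number 11 percentage points higher from compound 3 to compound 4 (beyond the scatter), within the scatter. The estimate for compound 4 is -75%, ranging from -100% to -30%.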

Compound 4, a percentage reported as activity, at one concentration (the size of the read-out at that concentration, not a potency): 7%
Beside the measured number, compound 4's estimate is 82 percentage points below it; the whole stated range lies below it.
By their numbers in this assay, from the lowest: compounds 1 and 3 (each within the scatter of the next); then compounds 4 and 2 (each within the scatter of the next).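

In this assay, one methoxy on the carbonyl aryl proves decisive (a change from 3,4-dimethoxyphenyl to 4-methoxyphenyl gives a number 93 percentage points higher from compound 3 to compound 4 (beyond the scatter)), so the tolerance suggested by the earlier pair does not extend to this change. The 4-methoxyphenyl compound also parts from the amino compound (a number 93 percentage points higher from compound 1 to compound 4 (beyond the scatter)) and instead matches the dichloro compound (a number 4 percentage points lower from compound 2 to compound 4 (within the scatter)). No data on hand explain this step.

As far as these compounds go, whether a hydroxy or ethoxy group on that aromatic carbon would keep the lower read-out remains open. Also open, from the compounds shown here alone, is how these compounds compare at other concentrations.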